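A few compounds are considered here, and "the series" means these few. Any claim that something is new, unique, unknown or untested is made for them only; others in the source may bear on it.

Measured compounds:
compound 1 `CCCCSc1sc2nc(-c3cccs3)cc(-c3ccccc3)c2c1N`, > 80 nM
compound 2 `CCCCS(=O)(=O)c1sc2nc(-c3cccs3)cc(-c3ccccc3)c2c1N`, 25 nM
compound 3 `Nc1c([S+]([O-])CCCF)sc2nc(-c3cccs3)cc(-c3ccccc3)c12`, 6.1 nM

In an assay for inhibition of 15-hydroxyprostaglandin dehydrogenase [NAD(+)] (Homo sapiens), read by fluorescence, with a stated time of 15 min, in the presence of a further agent that is not named here (on this read-out higher numbers stand for weaker inhibition and lower numbers for stronger inhibition), compound 1 gives only a limit, > 80 nM (the limit of > 80 nM in this assay, at which 1 of the 3 values shown sits), not a number. Compound 2 gives 25 nM and compound 3 gives 6.1 nM. Compound 3 thus stands lowest of the two numbers shown; its nearest neighbour is compound 2, a 4.1-fold lower number from compound 2 to compound 3 (0.61 log units; beyond the scatter). The other steps are an at least 3.2-fold lower number from compound 1 to compound 2 (0.50 log units; beyond the scatter) and an at least 13-fold lower number from compound 1 to compound 3 (1.11 log units; beyond the scatter).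

Compound 4 `CCCNC(=O)c1sc2nc(-c3cccs3)cc(-c3ccccc3)c2c1N` is not yet measured. It differs from compound 3 at the same position: a group of 6 heavy atoms (4 carbon, 1 nitrogen, 1 oxygen; no ring) in place of a group of 6 heavy atoms (3 carbon, 1 oxygen, 1 fluorine, 1 sulfur; no ring), on an aromatic carbon. All three measured steps change this one group, so all bear on the move, and together they show that the group here shifts the number over a wide span. Within the data shown here, none of them involves a propylcarbamoyl or any amide, so no step predicts its direction; the butylsulfanyl of compound 1, which also lacks an oxygen on the attachment atom, sits at the limit. A shift toward weaker inhibition is therefore expected, a 3.3-fold higher number from compound 3 to compound 4 (0.52 log units; beyond the scatter). For compound 4 the estimate in this assay is 20 nM, within 5 nM to 80 nM.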

Compound 4, half-maximal inhibitory concentration: > 7500 nM
Compound 4: no number, only a limit (the forecaster's own chance of this, stated with the estimate: 15%); at least 370-fold (2.57 log units) between middle value and limit.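

Compound 4 gives only a limit, not a number: the limit of > 7500 nM in this assay, at which 1 of the 4 values shown sits.

Placing propylcarbamoyl on this aromatic carbon gives an at least 1200-fold higher number from compound 3 to compound 4 (3.08 log units; beyond the scatter) and an at least 300-fold higher number from compound 2 to compound 4 (2.47 log units; beyond the scatter), so the position does not merely tune inhibition among the groups with a sulfur at the attachment atom: this one change takes the number far above both measured values. The step from compound 1 to compound 4 cannot be read, as both values are limits.

Still open, on these data alone, is whether the weak result follows the amide hydrogen, which the entering group carries and the leaving group lacks, or the carbonyl link itself; a tertiary amide with methyl and propyl on the nitrogen, or a butanoyl ketone, would separate the two. Also open, as far as these compounds go, is how a carboxylic acid or a longer chain on the amide would read at this position.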